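A few compounds are considered here, and "the series" means these few. Any claim that something is new, unique, unknown or untested is made for them only; others in the source may bear on it.

Measured compounds:
- compound 1 `CNC(=O)[C@@H](c1ccccc1)N1CCn2c(CC3CC3)nc(Cl)c2[C@@H]1CCc1ccc(C(F)(F)F)cc1`, a functional assay on CHO cells for antagonist activity at Orexin/Hypocretin receptor type 1 (Homo sapiens), read by FLIPR and calcium flux; on this read-out higher numbers stand for weaker inhibition and lower numbers for stronger inhibition: 1430 nM
- compound 2 `CNC(=O)[C@@H](c1ccccc1)N1CCn2c(COC)nc(Cl)c2[C@@H]1CCc1ccc(C(F)(F)F)cc1`, this assay: 1650 nM
- compound 3 `CCc1nc(I)c2n1CCN([C@@H](C(=O)NC)c1ccccc1)C2CCc1ccc(C(F)(F)F)cc1`, this assay: 717 nM

Compound 2 gives the highest of the three numbers in this assay. Its nearest neighbour is compound 1, whose number is lower only within the scatter; compound 3 sits furthest away, with a number lower beyond the scatter. Among the compounds with values here, the only single-point step available within the set is a 1.2-fold higher number from compound 1 to compound 2 (0.06 log units; within the scatter), which shows that swapping the substituent on that aromatic carbon of the shared core between two small groups leaves the read-out essentially unchanged.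

Compound 4 `CNC(=O)[C@@H](c1ccccc1)N1CCn2c(C(C)C)nc(Cl)c2[C@@H]1CCc1ccc(C(F)(F)F)cc1` is not yet measured. It differs from compound 2 by isopropyl in place of methoxymethyl on an aromatic carbon. This is a swap at the same aromatic carbon as the step from compound 1 to compound 2, and that step stayed within the scatter; the one acceptor of the methoxymethyl group is lost, but nothing in the measured set shows that acceptor mattering. The expectation is therefore a step of no more than the scatter, a 1.3-fold lower number from compound 2 to compound 4 (0.10 log units; within the scatter). For compound 4 the estimated value in this assay is 1300 nM, with a plausible range from 500 nM to 3500 nM.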

Compound 4, half-maximal inhibitory concentration: 313 nM
Compound 4: middle estimate off by 4.2-fold (0.62 log units), on the high side, outside the stated range (below it).
By their numbers in this assay, from the lowest: compound 4; then compounds 3, 1 and 2 (each within the scatter of the next, the first and the last beyond it).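

In this assay, this aromatic carbon between two ring nitrogen atoms is not indifferent to its substituent, despite the flat a 1.2-fold higher number from compound 1 to compound 2 (0.06 log units; within the scatter): isopropyl in place of methoxymethyl, with 3 heavy atoms in each group, gives a 5.3-fold lower number from compound 2 to compound 4 (0.72 log units; beyond the scatter), and isopropyl in place of cyclopropylmethyl gives a 4.6-fold lower number from compound 1 to compound 4 (0.66 log units; beyond the scatter). Loss of the oxygen does not by itself track with the lower number, as cyclopropylmethyl in compound 1 also has no oxygen, yet compound 1 stands within the scatter of compound 2. No measured evidence on the origin of these steps is available.

Going by these compounds, it remains open whether the lower number follows branching at the carbon bound to the ring, which a tert-butyl group, a directly attached cyclopropyl ring or an unbranched propyl chain would test. Also open, on these data alone, is whether the isopropyl step holds with iodo in place of chloro on the shared core.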